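The source may hold more compounds than are shown below. What is called first, only, known or untested is meant among the compounds shown, and "the series" means these compounds.

Compound 1 `Cc1ccc(-c2cn(C/C=C3\OC(=O)C(OCc4ccccc4)=C3OCc3ccccc3)nn2)cc1` and compound 2 `O=C1O/C(=C\Cn2cc(-c3cc(F)cc(F)c3)nn2)C(OCc2ccccc2)=C1OCc1ccccc1` share one core; compound 3 `Cc1ccc(-c2cn(C[C@H](O)[C@H]3OC(=O)C(OCc4ccccc4)=C3OCc3ccccc3)nn2)cc1` and compound 4 `O=C1O[C@H]([C@@H](O)Cn2cc(-c3cc(F)cc(F)c3)nn2)C(OCc2ccccc2)=C1OCc1ccccc1` share another, and the difference between the two cores is not broken down here. In a functional assay on MCF7 cells (Homo sapiens) for antiproliferative activity, read by MTT assay, with a stated time of 72 h (a higher number here means a weaker inhibitor, a lower number a stronger inhibitor), compound 1 gives only a limit, > 100000 nM. In this assay compound 2 likewise gives only a limit, > 100000 nM. The change between them, (3,5-difluorophenyl in place of 4-methylphenyl on an aromatic carbon), therefore makes a step whose size cannot be read: a step that the two limits leave unreadable from compound 1 to compound 2. In this assay compound 3 also gives only a limit, > 100000 nM. Across everything measured so far, there is the limit of > 100000 nM in this assay, at which 3 of the 3 values shown sit. Compound 4 carries the same change on the core of compound 3, (3,5-difluorophenyl in place of 4-methylphenyl on an aromatic carbon). Because the limit of > 100000 nM in this assay, at which 3 of the 3 values shown sit, holds for every value seen, and because a step that the two limits leave unreadable from compound 1 to compound 2 stays unreadable, the step from compound 3 to compound 4 is expected to be a step that the limit leaves unreadable from compound 3 to compound 4, an expectation resting only on all measured compounds sitting at that limit. Compound 4 is therefore expected to give about 150000 nM in this assay, with a range from 60000 nM to 500000 nM, most likely again reported as a limit rather than a number.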

Compound 4, half-maximal inhibitory concentration: 27700 nM
The estimate for compound 4 lay 5.4-fold (0.73 log units) above the measured number, outside the stated range (below it).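

In this assay, putting 3,5-difluorophenyl in place of 4-methylphenyl on the core of compound 3 gives an at least 3.6-fold lower number from compound 3 to compound 4 (0.55 log units; beyond the scatter), so on this core the change yields a real gain in potency and a measured number for compound 4. On the other core, compound 2 carries the same change and still gives only a limit, > 100000 nM. Steps between limits cannot be read, so this single readable step does not show that the change carries from one core to the other with a similar size, or that it has any effect on the core of compound 1, and it gives no reason for the gain, with nearly everything shown still at one limit: the limit of > 100000 nM in this assay, at which 3 of the 4 values shown sit.

The compounds shown leave open whether the gain depends on the 3,5-difluorophenyl group as a whole or on the particular core it sits on. They also leave open how an amine, a carboxylic acid or a longer chain would fare in the same place on the core of compound 3.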